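Glutamine for leucine swap on purine glycinamide series

The source may report more compounds than this note shows. Statements on the series, on what has been measured and on what is new or still open speak of the compounds shown alone.

Measured compounds:
- compound 1, `NC(=O)CC[C@H](NC(=O)CN(c1ncnc2c1ncn2C1CCCCO1)C1CC1)C(=O)OCc1ccccc1`: 37.8%
- compound 2, `CC(C)C[C@H](NC(=O)CN(c1ncnc2c1ncn2C1CCCCO1)C1CC1)C(=O)OCc1ccccc1`: 28.2%
- compound 3, `CC(C)C[C@H](NC(=O)CN(c1nc(Cl)nc2[nH]cnc12)C1CC1)C(=O)O`: 27%

In a functional assay on the whole organism (Tail, strain ICR) with Mus musculus as the target, in the tail flick test, with a stated time of 90 min, at a dose of 25 umol/kg by the oral route (a lower number here means a weaker effect, a higher number a stronger effect of the compound at the dose given), compound 2 gives 28.2% and compound 1 gives 37.8%. The change between them is carbamoylmethyl in place of isopropyl on a saturated chain carbon, two bonds along the chain from an amide-type nitrogen and a carbonyl carbon, and the step is a number 9.6 percentage points higher from compound 2 to compound 1 (within the scatter). Compound 3 and compound 2 share no single counted difference; how their cores differ is not broken down here. Compound 3 gives 27% in this assay, and its gap to compound 2 is within the scatter, while its gap to compound 1 is beyond it.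

Compound 4, `NC(=O)CC[C@H](NC(=O)CN(c1nc(Cl)nc2[nH]cnc12)C1CC1)C(=O)O`, has not been measured. It differs from compound 3 by carbamoylmethyl in place of isopropyl on a saturated chain carbon, two bonds along the chain from an amide-type nitrogen and a carbonyl carbon, the same kind of change as from compound 2 to compound 1. On the core of compound 3, a step of about a number 7 percentage points higher from compound 3 to compound 4 (within the scatter) is expected, resting on a number 9.6 percentage points higher from compound 2 to compound 1 (within the scatter) being within the scatter. For compound 4 the expected value in this assay is 34%, with a range from 20% to 48%.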

Compound 4, a percentage reported as activity, at one dose (the size of the read-out at that dose, not a potency): 41.1%
For compound 4 the middle estimate is 7.1 percentage points below the measured one, within the range that was stated.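

In this assay, carbamoylmethyl in place of isopropyl gives a number 14.1 percentage points higher from compound 3 to compound 4 (beyond the scatter) on the core of compound 3. The change can be carried between these two cores with no measurable difference in the size of its step: the same change on two cores in this assay, a number 9.6 percentage points higher (within the scatter) from compound 2 to compound 1 and a number 14.1 percentage points higher (beyond the scatter) from compound 3 to compound 4, 4.5 percentage points apart, within the scatter of two such steps. This rests on two pairs at a single dose, one of them within the scatter on its own, so it does not show that the change would transfer to any other core or give the same step at another dose.

Open, as far as these compounds go, is how a carboxylic acid, an amine or a longer chain on the same saturated chain carbon would compare with carbamoylmethyl. Also open, from the compounds shown here alone, is whether the step holds on a core combining features of these two.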